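The source may hold more compounds than are shown below. What is called first, only, known or untested is meant among the compounds shown, and "the series" means these compounds.

Measured so far in a functional assay on MCF7 cells (Homo sapiens) for antiproliferative activity, read by MTT assay, with a stated time of 3 days; on this read-out higher numbers stand for weaker inhibition and lower numbers for stronger inhibition:
- compound 1 `O=C1c2ccccc2C(=O)N1C/C=C\Cn1cc(C#Cc2ccc(Br)cc2)c(=O)[nH]c1=O`: > 100000 nM
- compound 2 `CCCCCc1ccc(C#Cc2cn(C/C=C/CN3C(=O)c4ccccc4C3=O)c(=O)[nH]c2=O)cc1`: 5600 nM

Compound 1 gives only a limit, not a number: > 100000 nM. This is the limit of > 100000 nM in this assay, at which 1 of the 2 values shown sits.

Compound 3 `CCCCC#Cc1cn(C/C=C\CN2C(=O)c3ccccc3C2=O)c(=O)[nH]c1=O` keeps the core of compound 1 but carries butyl in place of 4-bromophenyl on a triple-bonded carbon.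

Among the compounds with values here, no measured step isolates this change, so the expectation rests on thin evidence. Compound 2 reaches 5600 nM, which shows that a measurable value is possible with this kind of structure, although it differs from compound 1 in more than one place. The expected step of an at least 2.0-fold lower number from compound 1 to compound 3 (0.30 log units; that floor lies within the scatter) is modest and towards stronger inhibition, and a result reported only as a limit would be no surprise. For compound 3 the estimated value is 50000 nM, with an expected range from 12000 nM to 150000 nM.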

Compound 3, half-maximal inhibitory concentration: 45000 nM
Beside the measured number, compound 3's estimate is 1.1-fold (0.05 log units) above it; the measured number falls inside the stated range.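

In this assay, butyl in place of 4-bromophenyl on a triple-bonded carbon gives an at least 2.2-fold lower number from compound 1 to compound 3 (0.34 log units; beyond the scatter), so the number at this position does depend on the group it carries. A six-membered aromatic ring at this position is therefore not needed for a measurable value with this core, since butyl has no ring. The true size of the step remains unknown and only its floor can be read, because compound 1 is reported only as a limit: the limit of > 100000 nM in this assay, at which 1 of the 3 values shown sits.

As far as these compounds go, whether a longer chain, or a butyl chain ending in an amine or a carboxylic acid, would move the number further remains open. Within the data shown here, compound 2 differs from compound 1 and compound 3 in more than one place, so no step to it can be read for this change.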